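Methyl on the hydroxyethyl side chain, paired with a free amine

A few compounds are considered here, and "the series" means these few. Any claim that something is new, unique, unknown or untested is made for them only; others in the source may bear on it.

Series of anilides sharing the core of compound 1 `CCCCCCCCc1ccc(NC(=O)[C@H](N)CO)cc1` and differing only in the amino acid-derived acyl group. In an assay on isolated protein for inhibition of sphingosine kinase 1 (Homo sapiens), read by mobility shift assay (a lower number here means a stronger inhibitor, a higher number a weaker inhibitor), compound 1 gives 5000 nM. Compound 2 `CCCCCCCCc1ccc(NC(=O)[C@H](CO)NC)cc1` gives 2800 nM, and compound 3 `CCCCCCCCc1ccc(NC(=O)[C@@H](N)[C@@H](C)O)cc1` gives 650 nM. Compound 2 thus stands second highest of the three numbers; its nearest neighbour is compound 1, a 1.8-fold lower number from compound 1 to compound 2 (0.25 log units; within the scatter), and its furthest is compound 3, a 4.3-fold lower number from compound 2 to compound 3 (0.63 log units; beyond the scatter).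

Compound 4 `CCCCCCCCc1ccc(NC(=O)[C@H](N)[C@@H](C)O)cc1` carries the change (1-amino-2-hydroxypropyl in place of 2-hydroxy-1-(methylamino)ethyl on a carbonyl carbon). Within the data shown here, two measured steps bear on it. The same group change, read from the free amine of compound 1, gave a 7.7-fold lower number from compound 1 to compound 3 (0.89 log units; beyond the scatter); read from compound 2 itself, it gave a 4.3-fold lower number from compound 2 to compound 3 (0.63 log units; beyond the scatter). Compound 3 already carries 1-amino-2-hydroxypropyl, and compound 4 carries the same group with a different arrangement at its stereocentres, so the measured steps to compound 3 are the guide but not a direct copy. A modest lowering of the number in this assay is therefore expected, a 1.9-fold lower number from compound 2 to compound 4 (0.27 log units; within the scatter), while a result nearer to compound 1 cannot be ruled out. Compound 4 is estimated at 1500 nM, with a range from 500 nM to 5000 nM.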

Compound 4, half-maximal inhibitory concentration: 1600 nM
Beside the measured number, compound 4's estimate is 1.1-fold (0.03 log units) below it, within the range that was stated.
By their numbers in this assay, from the lowest: compound 3; then compounds 4, 2 and 1 (each within the scatter of the next, the first and the last beyond it).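

In this assay the 1-amino-2-hydroxypropyl group does not give one fixed outcome at this position, as a single stereocentre at a saturated chain carbon separates compound 3 from compound 4 (a 2.5-fold higher number from compound 3 to compound 4 (0.39 log units; beyond the scatter)), and that gap can be assigned to stereochemistry alone because of this: the fact that compounds 3 and 4 differ only in the configuration as drawn. Methyl in place of hydrogen on the saturated chain carbon still counts in the arrangement of compound 4 (a 3.1-fold lower number from compound 1 to compound 4 (0.49 log units; beyond the scatter)), a step beyond the scatter, though the same comparison in the arrangement of compound 3 reads larger (a 7.7-fold lower number from compound 1 to compound 3 (0.89 log units; beyond the scatter)). Against 2-hydroxy-1-(methylamino)ethyl, the arrangement of compound 4 is not separated (a 1.8-fold lower number from compound 2 to compound 4 (0.24 log units; within the scatter)), whereas that of compound 3 is (a 4.3-fold lower number from compound 2 to compound 3 (0.63 log units; beyond the scatter)), so the earlier gain holds only for one drawn configuration among the compounds shown.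

Open, going by these compounds, are the remaining arrangements of the two stereocentres in 1-amino-2-hydroxypropyl, and whether a methylamino group on that same side chain would add to or cancel the methyl step. Also open, on these data alone, is how an ethyl in place of that methyl, or a carboxylic acid in place of the hydroxyl, would read.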